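The source may hold more compounds than are shown below. What is called first, only, known or untested is meant among the compounds shown, and "the series" means these compounds.

Of the compounds shown here, three have so far been tested in an ADME assay on MRC5 cells (Homo sapiens) for inhibition, with a stated time of 72 h; a lower number here means that less compound is needed, a higher number that more compound is needed for the effect. Compound 1 `COc1cccc(OC)c1C(=O)Nc1c[nH]nc1C(=O)NC1CCN(Cc2ccccc2)C1` gives 38000 nM in this assay. Compound 2 `COc1cccc(OC)c1C(=O)Nc1c[nH]nc1C(=O)N[C@H]1CC[C@H](O)CC1` gives 34000 nM in this assay, a number so close to that of compound 1 that the two cannot be told apart. Compound 3 `CO[C@H]1CC[C@H](NC(=O)c2n[nH]cc2NC(=O)c2cc(Cl)cc(Cl)c2)CC1` gives 13000 nM in this assay, a clearly lower number than compound 2. Compound 2 therefore sits together with compound 1 at the high end of the three. Compound 4 `COc1cccc(OC)c1C(=O)Nc1c[nH]nc1C(=O)Nc1ccccn1` has not been measured; it differs from compound 2 in one place: pyridin-2-yl in place of 4-hydroxycyclohexyl on an amide-type nitrogen. Among the measured compounds shown here, no measured pair shows this kind of change, so its effect is unknown. In this assay a step of a 1.4-fold lower number from compound 2 to compound 4 (0.13 log units; within the scatter) is expected, small and without a clear direction. Compound 4 is estimated at 25000 nM, with a range from 8000 nM to 80000 nM.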

Compound 4, half-maximal effective concentration: > 50000 nM
Compound 4: only a limit was reported; the forecaster's own chance of this, stated with the estimate: 25%; middle value at least 2.0-fold (0.30 log units) away from the limit.
By their numbers in this assay, from the lowest: compound 3; then compounds 2 and 1 (each within the scatter of the next). At a limit, above all of these: compound 4.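

This is the first change shown on the amide-type nitrogen with the rest of the molecule held fixed: pyridin-2-yl in place of 4-hydroxycyclohexyl gives an at least 1.4-fold higher number from compound 2 to compound 4 (0.16 log units; that floor lies within the scatter) in this assay. Swapping the non-aromatic ring for this aromatic one therefore gave no sign of a lower number. The true size of the step cannot be read, because compound 4 has only a limit: the limit of > 50000 nM in this assay, at which 1 of the 4 values shown sits.

Still open, from the compounds shown here alone, is where the number would fall with a plain phenyl ring or a carboxylic acid on this nitrogen. Also open, going by these compounds, is whether pyridin-2-yl would act alike on the chlorine-bearing compound 3.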